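A Single Stereocentre Change at the Limit of the Assay

This account rests on a few compounds, and the source may have more. Where it says the series, first, only, none or still open, it means among the compounds named here.

- Compound 1 `CC1=C(CC[C@@H](C)C(=O)CCC2=CC(=O)OC2)C(C)(C)CCC1`: < 5 ug/mL
- Compound 2 `CO[C@H]1C[C@@]2(CC[C@@]3(O2)[C@H](C)CC[C@H]2C(C)(C)[C@@H](OC(C)=O)CC[C@@]23C)[C@H](OC)O1`: < 5 ug/mL
- Compound 3 `C[C@@H]1C[C@@H](O)[C@H]2C(C)(C)CCC[C@]2(C)[C@@]12CC[C@]1(COC(=O)C1)O2`: < 5 ug/mL

All three compounds were tested in a functional assay on A549 cells (Homo sapiens) for cytotoxicity, read by MTT assay, with a stated time of 72 h; a lower number here means a stronger inhibitor, a higher number a weaker inhibitor. Compound 2 gives < 5 ug/mL, which is a limit of the assay and not a number. The whole set shares this feature: the limit of < 5 ug/mL in this assay, at which 3 of the 3 values shown sit. Among the compounds with values here, the true position of compound 2 is therefore unknown, and no measured step between two compounds is available as a guide.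

Compound 4 `CO[C@@H]1C[C@@]2(CC[C@@]3(O2)[C@H](C)CC[C@H]2C(C)(C)[C@@H](OC(C)=O)CC[C@@]23C)[C@H](OC)O1` is the next compound to be tested, and it is compared here with compound 2: the two compounds have the same atoms and bonds and differ only in configuration as drawn: 1 of 8 stereo elements differ; a stereocentre at a saturated ring carbon is drawn R in compound 2 and S in compound 4. In plain terms, a stereocentre at a saturated ring carbon is drawn R in compound 2 and S in compound 4. With no atoms gained or lost, I expect no change beyond the usual scatter in this assay, and I expect no particular direction. The expected change is a step that the limit leaves unreadable from compound 2 to compound 4. The estimated value for compound 4 is 3 ug/mL, with an expected range of 1 ug/mL to 6 ug/mL.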

Compound 4, half-maximal inhibitory concentration: < 5 ug/mL
Compound 4 gave a limit, no number (the forecaster's own chance of this, stated with the estimate: 80%); the middle value lies beyond the limit too.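

No step can be read from compound 2 to compound 4, because both results are limits and not numbers: the limit of < 5 ug/mL in this assay, at which 4 of the 4 values shown sit.

The compounds shown leave open how strongly each one truly acts, and whether the configuration at that one saturated ring carbon changes the result at all.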